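Chain length and a dicarboxylic acid's grip on citrate lyase

A few compounds are considered here, and "the series" means these few. Any claim that something is new, unique, unknown or untested is made for them only; others in the source may bear on it.

Measured so far:
- compound 1, `CC(C)(CCCCCCCCCCCCC(C)(C)CC(=O)O)CC(=O)O`: 46000000 nM
- compound 2, `CC(C)(CCCCCCCCCCCCCCCCC(C)(C)CC(=O)O)CC(=O)O`: 320000000 nM

Both compounds are long saturated chains capped at each end by a carboxymethyl-bearing quaternary carbon. In an assay on liver for inhibition of ATP-citrate synthase (Rattus norvegicus) (a higher number here means a weaker inhibitor, a lower number a stronger inhibitor), compound 1 gives 46000000 nM, and compound 2 gives 320000000 nM, the highest of the two numbers and beyond the scatter of compound 1. Compound 2 is therefore the weaker inhibitor of the pair.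

Compound 3, `CC(C)(CCCCCCCCCCCCCCC(C)(C)CC(=O)O)CC(=O)O`, has not yet been measured. It differs from compound 2 by 1-(carboxymethyl)-1-methylethyl in place of 3-(carboxymethyl)-3-methylbutyl on a saturated chain carbon, ten or more bonds along the chain from a carbonyl carbon, so its chain length falls between those of compound 1 and compound 2. With only two measured points, no trend can be claimed, but a value between them is the plainest expectation. The step of a 2.7-fold lower number from compound 2 to compound 3 (0.43 log units; beyond the scatter) is expected to be a modest decrease. For compound 3 the estimated value is 120000000 nM, within a range of 40000000 nM to 350000000 nM.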

Compound 3, inhibition constant: 260000000 nM
The estimate for compound 3 lay 2.2-fold (0.34 log units) below the measured number; low and high end bracket the measured number.
By their numbers in this assay, from the lowest: compound 1; then compounds 3 and 2 (each within the scatter of the next).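

In this assay, 1-(carboxymethyl)-1-methylethyl in place of 3-(carboxymethyl)-3-methylbutyl on a saturated chain carbon, ten or more bonds along the chain from a carbonyl carbon, gives a 1.2-fold lower number from compound 2 to compound 3 (0.09 log units; within the scatter) and so separates compound 2 and compound 3 by no more than repeat measurements would. The opposite exchange at that place gives a 5.7-fold higher number from compound 1 to compound 3 (0.75 log units; beyond the scatter) and so leaves compound 1 alone at the low end, which means that among these three compounds the numbers do not follow chain size evenly. Nothing shown here accounts for this uneven result.

Still open, on these data alone, is whether a chain shorter than that of compound 1 would give a lower number. As far as these compounds go, it is also open what an amide in place of a carboxylic acid would do to these numbers.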